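Chain branching at the aryl ether of the shared core

The source may report more compounds than this note shows. Statements on the series, on what has been measured and on what is new or still open speak of the compounds shown alone.

Measured so far in an assay on cells with melanin-concentrating hormone receptor 1 (Homo sapiens) as the target, read by radioligand binding; on this read-out higher numbers stand for weaker inhibition and lower numbers for stronger inhibition:
compound 1 `CCCCCOc1cccc2ccc(N)nc12`: 580 nM
compound 2 `CCC(CC)C(C)Oc1cccc2ccc(N)nc12`: 191 nM
compound 3 `CC(CC(C)(C)C)Oc1cccc2cccnc12`: > 2000 nM

Compound 1 carries the highest of the two numbers recorded; its nearest neighbour, compound 2, sits a clear step lower, beyond the usual scatter. Compound 3 returns only a limit in this assay, not a number, so it supports no comparison of size (the limit of > 2000 nM in this assay, at which 1 of the 3 values shown sits).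

Compound 4 `CC(C)(C)CCOc1cccc2ccc(N)nc12` is the next member to be measured in this assay. Its difference from compound 1 is tert-butyl in place of propyl on a saturated chain carbon, two bonds along the chain from an oxygen on an aromatic ring. The same difference, cut one bond further out, reads pentyl to 3,3-dimethylbutyl.

Among the compounds with values here, no step between two measured compounds isolates this change, so the expectation rests on the bare numbers. Compound 2, with a branched chain at the same oxygen, gives 191 nM, a lower number than compound 1; compound 3 gives no number at all. On that basis compound 4 is expected to land at 400 nM, within 130 nM to 1200 nM. The expected step from compound 1 to compound 4 is a 1.5-fold lower number from compound 1 to compound 4 (0.16 log units; within the scatter), a modest move toward stronger inhibition that may not exceed the scatter.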

Compound 4, half-maximal inhibitory concentration: 201 nM
Beside the measured number, compound 4's estimate is 2.0-fold (0.30 log units) above it, and the stated range covers the measured number.
By their numbers in this assay, from the lowest: compounds 2 and 4 (each within the scatter of the next); then compound 1. At a limit, above all of these: compound 3.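

In this assay the series now has its first step that changes one place only, tert-butyl in place of propyl on a saturated chain carbon, two bonds along the chain from an oxygen on an aromatic ring, and it reads a 2.9-fold lower number from compound 1 to compound 4 (0.46 log units; beyond the scatter) as a gain in inhibition. This carbon therefore accepts a tert-butyl group with no loss on this read-out, but the change adds a carbon as well as branching, so the step does not separate chain size from branching. No measurement shown here accounts for the step.

A hexyl chain at the same oxygen, with the same carbon count as the 3,3-dimethylbutyl chain, would separate the two. On these data alone, whether an amine or a carboxylic acid is accepted on this carbon in place of tert-butyl remains open.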